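Para-fluoro on the pendant phenyl: a step from compound 2

The compounds below may be only part of what the source reports. "The series", "measured", "known", "first", "only" and "open" are said of these compounds alone.

Measured compounds:
compound 1 `Cc1ccc(C2=Nn3c(nnc3C(C)c3ccc(CC(C)C)cc3)SC2)cc1`, 5000 nM
compound 2 `CC(c1ccc(-c2ccccc2)c(F)c1)c1nnc2n1N=C(c1ccccc1)CS2`, 6700 nM

In a functional assay on Huh-7 cells (Homo sapiens) for inhibition, read by sulforhodamine B assay, with a stated time of 72 h (a lower number here means a stronger inhibitor, a higher number a weaker inhibitor), compound 2 gives 6700 nM, the higher of the two numbers, while compound 1 gives 5000 nM, a gap that lies within the scatter. Compound 3 `CC(c1ccc(-c2ccccc2)c(F)c1)c1nnc2n1N=C(c1ccc(F)cc1)CS2` differs from compound 2 by fluoro in place of hydrogen on an aromatic carbon. No step between measured compounds is shown for this change, so the step from compound 2 to compound 3 is expected to stay small, in no clear direction beyond the scatter: a 1.1-fold lower number from compound 2 to compound 3 (0.05 log units; within the scatter). Compound 3 is estimated at 6000 nM, with a range from 2500 nM to 15000 nM.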

Compound 3, half-maximal inhibitory concentration: 4900 nM
Compound 3: middle estimate off by 1.2-fold (0.09 log units), on the high side, within the range that was stated.
By their numbers in this assay, from the lowest: compounds 3, 1 and 2 (each within the scatter of the next).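

In this assay, the change from phenyl to 4-fluorophenyl gives a 1.4-fold lower number from compound 2 to compound 3 (0.14 log units; within the scatter) and so leaves the number within the scatter. Within the data shown here, this is the first comparison of compounds that differ in one place, which compounds 1 and 2 alone could not provide. Nothing shown offers a reason for this result. The compounds shown leave open whether a different group at this position, such as a methoxy group, an amine or a carboxylic acid, would move the number beyond the scatter.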